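The source may hold more compounds than are shown below. What is called first, only, known or untested is meant among the compounds shown, and "the series" means these compounds.

Measured so far: compound 2 `CC(=O)NC[C@H]1CN(c2ccc(OC[C@@H](O)CNc3ccncc3)c(F)c2)C(=O)O1` gives 17700000 nM in a physicochemical assay for solubility, read by HPLC; a lower number here means a less soluble compound, a higher number a more soluble compound; compound 1 `CC(=O)NC[C@H]1CN(c2ccc(OC[C@@H](O)CNc3ccc(C#N)cc3)c(F)c2)C(=O)O1` gives 47000 nM.

Compound 2 stands highest of the two numbers; its nearest neighbour is compound 1, separated by a 380-fold higher number from compound 1 to compound 2 (2.58 log units; beyond the scatter). Compound 3 `CC(=O)NC[C@H]1CN(c2ccc(OC[C@@H]3CNC(=O)O3)c(F)c2)C(=O)O1` differs from compound 2 by 2-oxo-1,3-oxazolidin-5-yl in place of 1-hydroxy-2-((pyridin-4-yl)amino)ethyl on a saturated chain carbon bound to an oxygen on an aromatic ring. Among the measured compounds shown here, no measured step covers this change; the single step seen, from compound 1 to compound 2, alters a different part of the molecule. The expected direction for compound 3 is therefore a lower number, with wide uncertainty, the step being an 8.9-fold lower number from compound 2 to compound 3 (0.95 log units; beyond the scatter). Compound 3 is estimated at 2000000 nM, within 200000 nM to 15000000 nM.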

Compound 3, solubility: 2720000 nM
For compound 3 the middle estimate is 1.4-fold (0.13 log units) below the measured one; the range from low to high includes it.
By their numbers in this assay, from the lowest: compound 1; then compound 3; then compound 2.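

At the place on a saturated chain carbon bound to an oxygen on an aromatic ring, 2-oxo-1,3-oxazolidin-5-yl in place of 1-hydroxy-2-((pyridin-4-yl)amino)ethyl gives a 6.5-fold lower number from compound 2 to compound 3 (0.81 log units; beyond the scatter) in this assay. Among the compounds shown here, this is the first reading at this place, and the number of compound 3 falls between those of compound 1 and compound 2. No evidence bears on the reason for this step.

Which part of the change carries the step remains open, since ring and chain change together. As far as these compounds go, how a primary amine or a carboxylic acid at this place would read is also open.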